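The source may hold more compounds than are shown below. What is called first, only, known or untested is meant among the compounds shown, and "the series" means these compounds.

Measured so far in a functional assay on SMMC-7721 cells (Homo sapiens) for cytotoxicity, read by MTT assay, with a stated time of 72 h (on this read-out lower numbers stand for stronger inhibition and higher numbers for weaker inhibition), as follows:
compound 1 `CC(C)=C1C(=O)N(c2ccc(Cl)cc2)N(c2ccc(Cl)cc2)C1=O` gives 45600 nM
compound 2 `O=C1C(=Cc2ccc(O)cc2)C(=O)N(c2ccc(Cl)cc2)N1c1ccc(Cl)cc1` gives 20600 nM

Compound 2 holds the lower number of the two, with a gap to compound 1 beyond the scatter. Compound 3 `CN(C)c1ccc(C=C2C(=O)N(c3ccc(Cl)cc3)N(c3ccc(Cl)cc3)C2=O)cc1` has dimethylamino in place of hydroxy on an aromatic carbon, para to a large group (dimethylamino in place of hydroxy on an aromatic carbon). Within the data shown here, no step between measured compounds covers this change, so the expectation rests on compound 2 at 20600 nM alone. In this assay the expected step stays within the scatter, with no firm direction: a 1.1-fold lower number from compound 2 to compound 3 (0.06 log units; within the scatter) as the estimate. The estimate for compound 3 is 18000 nM with an expected range from 6000 nM to 50000 nM for repeated measurements.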

Compound 3, half-maximal inhibitory concentration: > 128000 nM
Compound 3 gave a limit, no number; the forecaster's own chance of this, stated with the estimate: 10%; middle value at least 7.1-fold (0.85 log units) away from the limit.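

In this assay compound 3 gives a limit of the assay and not a number: the limit of > 128000 nM in this assay, at which 1 of the 3 values shown sits. Dimethylamino in place of hydroxy, on an aromatic carbon para to a large group, gives an at least 6.2-fold higher number from compound 2 to compound 3 (0.79 log units; beyond the scatter). Among these compounds, this is the first one-place comparison, and it shows that the group at this position can shift the read-out beyond the scatter. Still open, on these data alone, is whether the shift follows the departure of hydroxy or the arrival of dimethylamino; a methoxy group or a primary amine at the same position would separate the two. The step also has no upper bound.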